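Methylated pyrazole in place of the hydroxymethylcyclopropyl amide

A few compounds are considered here, and "the series" means these few. Any claim that something is new, unique, unknown or untested is made for them only; others in the source may bear on it.

Measured compounds:
compound 1 `CC1(C)Cc2c(sc(NC(=O)c3cccnc3O)c2C(N)=O)C(C)(C)O1` — 190 nM
compound 2 `CC1(C)Cc2c(sc(NC(=O)c3ccn[nH]3)c2C(N)=O)C(C)(C)O1` — 3 nM
compound 3 `CC1(C)Cc2c(sc(NC(=O)C3(CO)CC3)c2C(N)=O)C(C)(C)O1` — 15 nM

The three compounds share one core and differ only in the group attached to the carbonyl carbon of the amide. In an assay on cells for positive allosteric modulation of Cystic fibrosis transmembrane conductance regulator variant F508del (Homo sapiens), with stated times of 10 min and 7 s, in the presence of a further agent that is not named here (on this read-out higher numbers stand for an effect only at larger amounts of compound and lower numbers for an effect already at smaller amounts), compound 1 gives 190 nM, compound 2 gives 3 nM and compound 3 gives 15 nM. Compound 3 therefore stands second highest of the three numbers: the step of a 13-fold lower number from compound 1 to compound 3 (1.10 log units; beyond the scatter) sets it well apart from compound 1, while the step of a 5.0-fold higher number from compound 2 to compound 3 (0.70 log units; beyond the scatter) places it clearly above compound 2 in this assay.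

Compound 4 `Cc1cn[nH]c1C(=O)Nc1sc2c(c1C(N)=O)CC(C)(C)OC2(C)C` is the next structure in line. The change from compound 3 is 4-methyl-1H-pyrazol-5-yl in place of 1-(hydroxymethyl)cyclopropyl on a carbonyl carbon. The measured step that bears on it most directly is a 5.0-fold higher number from compound 2 to compound 3 (0.70 log units; beyond the scatter), which, read in the reverse direction, shows that a pyrazole on the carbonyl carbon gave a modestly lower number than the hydroxymethylcyclopropyl group. Within the data shown here, compound 4 differs from compound 2 only by the methyl on the pyrazole, and no measured pair speaks to that methyl. He therefore expects a step of about a 3.8-fold lower number from compound 3 to compound 4 (0.57 log units; beyond the scatter) in this assay, towards a lower number. His estimate for compound 4 is 4 nM, within a range of 1.5 nM to 12 nM.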

Compound 4, half-maximal effective concentration: 2 nM
Compound 4: the middle estimate sits 2.0-fold (0.30 log units) above what was measured; measured number inside the range.
By their numbers in this assay, from the lowest: compounds 4 and 2 (each within the scatter of the next); then compound 3; then compound 1.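

In this assay, among these compounds, the methyl is the first change at this position that cannot be told from the scatter: with a 1.5-fold lower number from compound 2 to compound 4 (0.18 log units; within the scatter), methyl in place of hydrogen on an aromatic carbon of the pyrazole gives no readable difference. The standing of the pyrazole on the carbonyl carbon carries over to the methylated group, since a 7.5-fold lower number from compound 3 to compound 4 (0.88 log units; beyond the scatter) and a 95-fold lower number from compound 1 to compound 4 (1.98 log units; beyond the scatter) both lie beyond the scatter, the second of them a large step. The data offer no measurement that would explain any of these steps.

The compounds shown leave open whether a group larger than methyl, such as ethyl or methoxy, could take the place of that methyl and still stay within the scatter of compound 2. They also leave open how another five-membered aromatic ring, such as an imidazole or a triazole, would compare with 4-methyl-1H-pyrazol-5-yl on the same carbonyl carbon, and whether an amine or a carboxylic acid on the pyrazole would fit alongside these numbers.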